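Swapping isopropyl for methoxy on an inactive pair

The source may hold more compounds than are shown below. What is called first, only, known or untested is meant among the compounds shown, and "the series" means these compounds.

Compound 1 `COc1ccc(Nc2nc(SCc3cn(CC(=O)NC(=O)Nc4ccccn4)nn3)nc(-c3ccc(C(C)C)cc3)c2C#N)cc1` gives > 64000 nM in a functional assay on MCF7 cells (Homo sapiens) for inhibition, read by MTT assay, with a stated time of 72 h (on this read-out higher numbers stand for weaker inhibition and lower numbers for stronger inhibition), a limit of the assay and not a number.
Compound 2 `Cc1ccc(-c2nc(SCc3cn(CC(=O)NC(=O)Nc4ccccn4)nn3)nc(Nc3ccc(C(C)C)cc3)c2C#N)cc1` gives > 64000 nM in this assay, again a limit rather than a number.

Among the compounds with values here, compound 2 therefore stands at the edge of what this assay can report, and the only other value shown sits at the same edge: the limit of > 64000 nM in this assay, at which 2 of the 2 values shown sit. Compound 3 `COc1ccc(Nc2nc(SCc3cn(CC(=O)NC(=O)Nc4ccccn4)nn3)nc(-c3ccc(C)cc3)c2C#N)cc1` is made from compound 2 by the change (methoxy in place of isopropyl on an aromatic carbon). Within the data shown here, its two measured relatives give no measured step to lean on, and both carry the same limit, so no movement beyond the usual scatter is expected in this assay; the step from compound 2 to compound 3 is estimated as a number no higher from compound 2 to compound 3 (the limit leaves the size open). For compound 3 the expected outcome in this assay is 64000 nM, within 25000 nM to 150000 nM, most likely reported as a limit once more.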

Compound 3, half-maximal inhibitory concentration: 23400 nM
Compound 3: middle estimate off by 2.7-fold (0.44 log units), on the high side, outside the stated range (below it).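

In this assay, methoxy in place of isopropyl on the (4-isopropylphenyl)amino group gives an at least 2.7-fold lower number from compound 2 to compound 3 (0.43 log units; beyond the scatter), while methyl in place of isopropyl on the 4-isopropylphenyl group gives an at least 2.7-fold lower number from compound 1 to compound 3 (0.43 log units; beyond the scatter). Among these three compounds, compound 3 is the only one without an isopropyl group and the first to give a number instead of a limit, so a change at either of these two places goes with a lower number. The true size of both steps remains unknown because each starts from a limit: the limit of > 64000 nM in this assay, at which 2 of the 3 values shown sit.

The compounds shown do not reveal whether one of the two replacements matters more than the other. They also leave open how a hydroxyl group, an amine or a longer chain would behave in place of the isopropyl group.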